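Coumarin–lipoic acid conjugates: cytotoxicity on PC-12 cells

A few compounds are considered here, and "the series" means these few. Any claim that something is new, unique, unknown or untested is made for them only; others in the source may bear on it.

Measured so far:
- compound 1, `CC(=O)c1cc2ccc(OCCCn3cc(CNC(=O)CCCCC4CCSS4)nn3)cc2oc1=O`, 40.7%
- compound 2, `O=C(CCCCC1CCSS1)NCc1cn(CCCOc2ccc3cc(-c4ccccc4)c(=O)oc3c2)nn1`, 23.1%

Both compounds were tested in a functional assay on PC-12 cells (Rattus norvegicus) for cytotoxicity, read by MTT assay, with stated times of 3 h and 2 h, tested at 50 uM; on this read-out higher numbers stand for a stronger effect at the one concentration tested and lower numbers for a weaker effect. Compound 1 gives 40.7% and stands highest of the two numbers; the nearest is compound 2, which gives 23.1% in this assay. Going by the values given here, the single measured step, a number 17.6 percentage points lower from compound 1 to compound 2 (beyond the scatter), lies beyond the scatter and is of modest size.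

Compound 3, `O=C(CCCCC1CCSS1)NCc1cn(CCCOc2ccc3cc(-c4ccc(Cl)cc4)c(=O)oc3c2)nn1`, is not yet measured. Its difference from compound 1 is 4-chlorophenyl in place of acetyl on an aromatic carbon. Among the compounds with values here, the only measured step that bears on this change is a number 17.6 percentage points lower from compound 1 to compound 2 (beyond the scatter), since compound 2 also carries an aryl ring where compound 1 carries acetyl; compound 3 differs from compound 2 only in the chlorine on that ring, and no step tells what that chlorine adds. The expectation is therefore a downward step of about the same size as that from compound 1 to compound 2, with the chlorine left as an open question. Compound 3 is expected to show a number 18.7 percentage points lower from compound 1 to compound 3 (beyond the scatter) in this assay. The estimate for compound 3 is 22%, with a range from 10% to 36%.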

Compound 3, a percentage reported as activity, at one concentration (the size of the read-out at that concentration, not a potency): 79.4%
Estimate against measurement, compound 3: 57.4 percentage points below, and the stated range ends below it.
By their numbers in this assay, from the lowest: compound 2; then compound 1; then compound 3.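

In this assay, an aryl group at this aromatic carbon of the core does not by itself set the direction of the change from acetyl: the phenyl of compound 2 gave a number 17.6 percentage points lower from compound 1 to compound 2 (beyond the scatter), whereas the 4-chlorophenyl of compound 3 gives a number 38.7 percentage points higher from compound 1 to compound 3 (beyond the scatter) in the opposite direction. The chloro in place of hydrogen on that aryl ring reverses the outcome, with a number 56.3 percentage points higher from compound 2 to compound 3 (beyond the scatter) as the step, so the swap of acetyl for an aryl group cannot be read as a single effect of adding an aromatic ring. Nothing at hand explains why one chlorine on that ring moves the read-out this far.

On these data alone, it remains open whether this rise belongs to chloro alone or also appears with a bromo, methyl or methoxy group on the same ring, and whether chloro elsewhere on that ring gives a similar number. As far as these compounds go, all three numbers come from one concentration and show the size of the read-out there, so whether their order holds across a range of concentrations also remains open.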